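Methoxyphenyl in Place of a Methoxypyridinylmethyl Urea Arm

A few compounds are considered here, and "the series" means these few. Any claim that something is new, unique, unknown or untested is made for them only; others in the source may bear on it.

Measured compounds in an ADME assay on the whole organism (Rattus norvegicus, strain Sprague-Dawley) for pharmacokinetics, read by LC-MS, with a stated time of 24 h, at a dose of 5 mg/kg by the intravenous route; on this read-out higher numbers stand for fast clearance and lower numbers for slow clearance:
Compound 1 `Cc1ccc(CNC(=O)Nc2ccc(Oc3ncnc4cc(N(C)C)ccc34)cc2)cn1`: 5.6 mL/min/kg
Compound 2 `COc1ccc(CNC(=O)Nc2ccc(Oc3ncnc4cc(N(C)C)ccc34)cc2)cn1`: 24.7 mL/min/kg

Among the measured compounds shown here, compound 2 stands highest of the two numbers in this assay; its nearest neighbour is compound 1, and the step of a 4.4-fold higher number from compound 1 to compound 2 (0.64 log units; beyond the scatter) is the only measured step in the set. Compound 3 `COc1ccc(NC(=O)Nc2ccc(Oc3ncnc4cc(N(C)C)ccc34)cc2)cc1` differs from compound 2 at the urea: 4-methoxyphenyl in place of (6-methoxypyridin-3-yl)methyl on an amide-type nitrogen. For the measured compounds named here, no measured step bears on this change; the step from compound 1 to compound 2 concerns only a methoxy in place of a methyl on an aromatic carbon, and says nothing about the urea arm. In this assay the step from compound 2 to compound 3 is therefore expected to be no larger than the scatter, a 1.2-fold lower number from compound 2 to compound 3 (0.09 log units; within the scatter), with a wide range reflecting the lack of a comparable step. Compound 3 is estimated at 20 mL/min/kg, between 7 mL/min/kg and 55 mL/min/kg.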

Compound 3, clearance: 5.6 mL/min/kg
For compound 3 the middle estimate is 3.6-fold (0.55 log units) above the measured one; the measured number lies below the stated range.
By their numbers in this assay, from the lowest: compounds 1 and 3 (each within the scatter of the next); then compound 2.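

In this assay the urea arm proves able to move the number: 4-methoxyphenyl in place of (6-methoxypyridin-3-yl)methyl on the amide-type nitrogen gives a clear step (a 4.4-fold lower number from compound 2 to compound 3 (0.64 log units; beyond the scatter)). The same 4-methoxyphenyl set against the (6-methylpyridin-3-yl)methyl arm gives no step beyond the scatter (no change at the digits printed from compound 1 to compound 3 (within the scatter)), so among these three arms only the one carried by compound 2 stands apart. Nothing shown here accounts for why that arm differs from the other two.

Open, on these data alone, is whether the ring nitrogen or the methylene of the arm decides the outcome, since compound 3 differs from compound 2 in both at once. Also open, as far as these compounds go, is how a 4-methylphenyl arm, or a longer chain ending in an amine, would read in this assay on this urea nitrogen.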